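Replacing a Pyridylmethyl Arm with a Methylphenylcarbonyl Arm

This account rests on a few compounds, and the source may have more. Where it says the series, first, only, none or still open, it means among the compounds named here.

Of the compounds shown here, three built on one shared core have been measured in an assay on isolated protein for inhibition of Long-chain-fatty-acid--CoA ligase 1 (Homo sapiens), read by mass spectrometry, with a stated time of 90 min, in the presence of a further agent that is not named here; on this read-out lower numbers stand for stronger inhibition and higher numbers for weaker inhibition. Compound 1, `Cc1ccccc1Cc1nc2cc(O[C@H]3CC[C@@H](C(=O)O)CC3)ccc2n1C`, gives 7800 nM. Compound 2, `Cn1c(Cc2cccc(C(F)(F)F)c2)nc2cc(O[C@H]3CC[C@@H](C(=O)O)CC3)ccc21`, gives 190 nM in this assay. Compound 3, `Cn1c(Cc2cccnc2)nc2cc(O[C@H]3CC[C@@H](C(=O)O)CC3)ccc21`, gives 141000 nM in this assay, the highest of the three numbers; the steps of an 18-fold higher number from compound 1 to compound 3 (1.26 log units; beyond the scatter) and a 740-fold higher number from compound 2 to compound 3 (2.87 log units; beyond the scatter) both lie beyond the scatter.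

Compound 4, `Cc1cccc(C(=O)c2nc3cc(O[C@H]4CC[C@@H](C(=O)O)CC4)ccc3n2C)c1`, differs from compound 3 at one place: (3-methylphenyl)carbonyl in place of (pyridin-3-yl)methyl on an aromatic carbon. Among the compounds with values here, two measured steps bear on this change. The step of a 740-fold higher number from compound 2 to compound 3 (2.87 log units; beyond the scatter) shows what the pyridin-3-yl cost against a 3-(trifluoromethyl)phenyl, and the step of an 18-fold higher number from compound 1 to compound 3 (1.26 log units; beyond the scatter) shows what it cost against a 2-methylphenyl; the step of a 41-fold lower number from compound 1 to compound 2 (1.61 log units; beyond the scatter) adds that the 3-(trifluoromethyl)phenyl outperformed the 2-methylphenyl. From the compounds shown here alone, nothing measured here speaks to a carbonyl standing in place of the saturated chain carbon, so that part of the change is untested. On balance a large drop in the number is expected in this assay. Compound 4 is therefore estimated at 1500 nM, within 150 nM to 15000 nM. The expected step is a 94-fold lower number from compound 3 to compound 4 (1.97 log units; beyond the scatter).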

Compound 4, half-maximal inhibitory concentration: > 200000 nM
Compound 4: only a limit was reported; the forecaster's own chance of this, stated with the estimate: 5%; middle value at least 130-fold (2.12 log units) away from the limit.
By their numbers in this assay, from the lowest: compound 2; then compound 1; then compound 3. At a limit, above all of these: compound 4.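

In this assay compound 4 yields a limit and not a number: the limit of > 200000 nM in this assay, at which 1 of the 4 values shown sits. The step of an at least 25-fold higher number from compound 1 to compound 4 (1.40 log units; beyond the scatter) lies beyond the scatter, and it shows what compounds 1 and 2 could not: a six-membered aromatic ring of carbon only, on this aromatic carbon of the five-membered ring, does not by itself keep a measurable number, as the (3-methylphenyl)carbonyl arm ends at the limit while the 2-methylbenzyl arm does not. The step of an at least 1.4-fold higher number from compound 3 to compound 4 (0.15 log units; that floor lies within the scatter) has a floor within the scatter, so the data do not rank this arm against the (pyridin-3-yl)methyl arm, and the exchange of that arm gives no measured gain, only a value that cannot be placed against it.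

From the compounds shown here alone, the change alters the link to the ring and the group on the ring together, so it stays open whether the carbonyl or the 3-methyl placement accounts for the result, a question that a 3-methylbenzyl arm or a (3-(trifluoromethyl)phenyl)carbonyl arm would address. Also open, going by these compounds, is how an ether oxygen or a hydroxyl-bearing carbon would behave in the place of the carbonyl.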